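Permeability after chain extension in the shared core

The source may report more compounds than this note shows. Statements on the series, on what has been measured and on what is new or still open speak of the compounds shown alone.

Compound 1 `CN(C[C@H]1Cc2ncccc2CN1)[C@H]1CCCc2cccnc21` stands highest of the three measured numbers in an ADME assay for permeability, using PAMPA, with a stated time of 4 h, at pH 5.5 (on this read-out lower numbers stand for lower permeability and higher numbers for higher permeability), giving 460 nm/s. Compound 2 `CN(C)CCCCN(C[C@H]1Cc2ncccc2CN1)[C@H]1CCCc2cccnc21` gives 2 nm/s and compound 3 `CN(CCCCN(C[C@H]1Cc2ncccc2CN1)[C@H]1CCCc2cccnc21)C1CCC(F)(F)CC1` gives 15 nm/s in this assay. The step to compound 4 `c1cnc2c(c1)CN[C@@H](CN(CCCCNC1CCOCC1)[C@H]1CCCc3cccnc31)C2` changes compound 1 by 3-((oxan-4-yl)amino)propyl in place of hydrogen on a saturated chain carbon bound to an amine nitrogen. The measured step that bears on it most is a 230-fold lower number from compound 1 to compound 2 (2.36 log units; beyond the scatter), a 3-(dimethylamino)propyl entering at the same place; the step of a 7.5-fold higher number from compound 2 to compound 3 (0.88 log units; beyond the scatter) shows that a larger group on the chain amine nitrogen recovers part of that number. A large fall in this assay is therefore expected for compound 4, estimated as a 58-fold lower number from compound 1 to compound 4 (1.76 log units; beyond the scatter). Compound 4 is expected to give about 8 nm/s in this assay, within 2 nm/s to 40 nm/s.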

Compound 4, apparent permeability: 2 nm/s
Estimate against measurement, compound 4: 4.0-fold (0.60 log units) above; the range from low to high includes it.
By their numbers in this assay, from the lowest: compounds 2 and 4 (each within the scatter of the next); then compound 3; then compound 1.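

In this assay, the large fall is not confined to the dimethylamino chain end: the step with 3-((oxan-4-yl)amino)propyl is a 230-fold lower number from compound 1 to compound 4 (2.36 log units; beyond the scatter), while (oxan-4-yl)amino in place of dimethylamino gives no change at the digits printed from compound 2 to compound 4 (within the scatter). The higher number with 4,4-difluorocyclohexyl does not carry over to the oxane ring, with a 7.5-fold lower number from compound 3 to compound 4 (0.88 log units; beyond the scatter). No measurement in hand gives a cause for these steps.

Still open, on these data alone, is whether a shorter chain, or an amide in place of the chain amine, keeps more of the number of compound 1. Also open, as far as these compounds go, is whether a cyclohexyl group without fluorine behaves like 4,4-difluorocyclohexyl.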